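The compounds below may be only part of what the source reports. "The series", "measured", "known", "first", "only" and "open" are said of these compounds alone.

Measured so far in a functional assay on cells (Splenocyte, Mus musculus, strain BALB/c) for inhibition, read by scintillation counting and thymidine incorporation, with stated times of 48 h and 8 h; on this read-out higher numbers stand for weaker inhibition and lower numbers for stronger inhibition:
- compound 1, `COc1cc(-c2nc(Cc3c[nH]c4ccccc34)no2)cc(OC)c1OC`: 11000 nM
- compound 2, `COc1cccc(-c2nc(Cc3c[nH]c4ccccc34)no2)c1`: 18500 nM

Compound 2 stands with the higher of the two numbers in this assay, but its gap to compound 1 is within the scatter of repeated measurements, so the two values cannot be ordered against each other. No change between measured compounds is large enough to be called a step; the two numbers shown simply sit close together.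

Compound 3, `COc1cc(OC)cc(-c2nc(Cc3c[nH]c4ccccc34)no2)c1`, is not yet measured. From compound 2 it differs by methoxy in place of hydrogen on an aromatic carbon. The result keeps the shared core of compound 2 and moves the substitution pattern toward that of compound 1, which carries three methoxy groups on the same ring.

Going by the values given here, nothing among the measured compounds points to a step beyond the scatter for this change. Compound 3 is therefore expected to give a number close to compound 2, with at most a slight lowering, because compound 1 gives 11000 nM and compound 2 gives 18500 nM in this assay. The expected step of a 1.4-fold lower number from compound 2 to compound 3 (0.15 log units; within the scatter) is thus small. For compound 3 the estimate is 13000 nM, with a range from 6000 nM to 28000 nM.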

Compound 3, half-maximal inhibitory concentration: > 50000 nM
Compound 3 was reported as a limit (the forecaster's own chance of this, stated with the estimate: 10%); middle value at least 3.8-fold (0.58 log units) away from the limit.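

In this assay, methoxy in place of hydrogen on this aromatic carbon, meta to a large group and meta to a methoxy group, is not a neutral change: it gives an at least 2.7-fold higher number from compound 2 to compound 3 (0.43 log units; beyond the scatter). Hydrogen in place of methoxy on an aromatic carbon gives an at least 4.5-fold higher number from compound 1 to compound 3 (0.65 log units; beyond the scatter), so the read-out does not move in a single direction with the amount of methoxy on this ring across the three compounds shown. Compound 3 is reported only as a limit, so neither step has a known upper end: the limit of > 50000 nM in this assay, at which 1 of the 3 values shown sits.

Whether the rise in the number belongs to methoxy in particular or to any group on this carbon stays open, as the compounds shown hold only hydrogen or methoxy on this ring, with nothing such as fluorine, a hydroxyl or an amine to compare. Also open, on these data alone, are the actual value of compound 3 and whether the methoxy present in compound 1 and absent from compound 3 could be exchanged for a hydroxyl or a longer ethoxy chain while the number stays as low.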